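This account rests on a few compounds, and the source may have more. Where it says the series, first, only, none or still open, it means among the compounds named here.

Working notes on the series. Compound 1 `Nc1ncnc2c1ncn2Cc1ccc(F)cc1` in an assay on isolated protein for inhibition of Rho-associated protein kinase 1 (Homo sapiens), tested at 30 uM (on this read-out higher numbers stand for more inhibition at the one concentration tested (going by the name of the read-out) and lower numbers for less inhibition), gives 0%, the lowest of the two numbers in hand. Compound 2 `Cn1c(-c2ccc([S+](C)[O-])cc2)nc2c(Sc3ccccc3)ncnc21` in this assay gives 1%; the two values lie within the scatter of each other, so they show the same thing. Compound 3 `Fc1ccc(Cn2cnc3c(Sc4ccc(F)cc4)ncnc32)cc1` is unmeasured. It differs from compound 1 by (4-fluorophenyl)sulfanyl in place of amino on an aromatic carbon. With compound 2 at 1% also carrying a sulfanyl-linked ring on the core, the step of a number 5 percentage points higher from compound 1 to compound 3 (within the scatter) is expected to stay within the scatter. Compound 3 is estimated at 5%, between 0% and 25%.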

Compound 3, a percentage reported as inhibition, at one concentration (the size of the read-out at that concentration, not a potency): 0%
Compound 3: the middle estimate sits 5 percentage points above what was measured; the range from low to high includes it.
By their numbers in this assay, from the lowest: compounds 1, 3 and 2 (each within the scatter of the next).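

In this assay, (4-fluorophenyl)sulfanyl in place of amino on this aromatic carbon gives no change at the digits printed from compound 1 to compound 3 (within the scatter) and so does not raise inhibition at the one concentration tested. Replacing the amino group with this much larger aromatic group therefore leaves the read-out unmoved, and the amino group is not needed to hold the value of compound 1. Nothing available explains this result. From the compounds shown here alone, whether a methylamino group, a carboxylic acid or a morpholine at this carbon would raise inhibition remains open. So does the effect of replacing the 4-fluorobenzyl group.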